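The compounds below may be only part of what the source reports. "The series", "measured", "known", "first", "only" and "open" are said of these compounds alone.

Three compounds have been measured in a functional assay on HeLa cells (Homo sapiens) for antiproliferative activity, read by MTT assay, with a stated time of 24 h; on this read-out lower numbers stand for stronger inhibition and higher numbers for weaker inhibition:

Compound 1 `Sc1nnc(-c2ccc3c(c2)OCCO3)n1-c1ccccc1` gives 51900 nM.
Compound 2 `c1ccc(CSc2nnc(-c3ccc4c(c3)OCCO4)n2-c2ccccc2)cc1` gives 32800 nM.
Compound 3 `O=[N+]([O-])c1ccccc1CSc1nnc(-c2ccc3c(c2)OCCO3)n1-c1ccccc1` gives 69800 nM.

Compound 3 has the highest number of the three. Against compound 1 it stands a 1.3-fold higher number from compound 1 to compound 3 (0.13 log units; within the scatter), while against compound 2 the difference is a 2.1-fold higher number from compound 2 to compound 3 (0.33 log units; beyond the scatter).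

Compound 4 `O=[N+]([O-])c1ccc(CSc2nnc(-c3ccc4c(c3)OCCO4)n2-c2ccccc2)cc1` differs from compound 3 in one place: 4-nitrophenyl in place of 2-nitrophenyl on a saturated chain carbon bound to a sulfur. For the measured compounds named here, no measured pair shows a nitro group moved from one position of the benzyl ring to another, so the only steps that bear on it are those that introduce the nitro group or the nitrobenzyl as a whole. From compound 1 the nitrobenzyl brought a 1.3-fold higher number from compound 1 to compound 3 (0.13 log units; within the scatter), and from compound 2 the nitro brought a 2.1-fold higher number from compound 2 to compound 3 (0.33 log units; beyond the scatter). These steps are small, and a mere relocation of the same group is not expected to produce more than they did. The expected step in this assay from compound 3 to compound 4 is therefore a 1.3-fold lower number from compound 3 to compound 4 (0.10 log units; within the scatter), a change that would fall within the scatter, with a slight lean toward a lower number because compound 2 without the nitro gives 32800 nM.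

Compound 4 is thus estimated at 55000 nM, with a range from 22000 nM to 130000 nM.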

Compound 4, half-maximal inhibitory concentration: 36200 nM
Compound 4: middle estimate off by 1.5-fold (0.18 log units), on the high side; the measured number falls inside the stated range.
By their numbers in this assay, from the lowest: compounds 2, 4, 1 and 3 (each within the scatter of the next, the first and the last beyond it).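

In this assay, shifting the nitro group around the ring gives a 1.9-fold lower number from compound 3 to compound 4 (0.29 log units; within the scatter), a step within the scatter, so 2-nitrophenyl and 4-nitrophenyl on a saturated chain carbon bound to a sulfur are not told apart in this series. Set against the plain benzyl compound, 4-nitrophenyl gives a 1.1-fold higher number from compound 2 to compound 4 (0.04 log units; within the scatter), also within the scatter, whereas 2-nitrophenyl gave a 2.1-fold higher number from compound 2 to compound 3 (0.33 log units; beyond the scatter), which is beyond the scatter but modest; that separation from the unsubstituted benzyl is therefore seen with only one of the two nitro placements. Against the hydrogen on the sulfur, 4-nitrobenzyl gives a 1.4-fold lower number from compound 1 to compound 4 (0.16 log units; within the scatter), again within the scatter, as was the step from the same starting point to 2-nitrobenzyl.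

No measurement at hand offers an explanation for any of these numbers. From the compounds shown here alone, it remains open whether an amine or a carboxylic acid on the benzyl ring, or a longer chain on the sulfur in place of the benzyl, would shift the number in this assay by more than the scatter.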